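The compounds below may be only part of what the source reports. "The series", "measured", "known", "first", "only" and "open" are said of these compounds alone.

Of the compounds shown here, three built on a shared core have been measured in a functional assay on OVCAR-8 cells (Homo sapiens) for antiproliferative activity; a lower number here means a stronger inhibitor, a higher number a weaker inhibitor. Compound 1 `Cn1ncc(Cl)c1-c1cc(C(=O)N[C@@H]2CN[C@H](CC(=O)O)C[C@H]2c2ccc(Cl)c(Cl)c2)oc1Cl` carries a carboxy group on a saturated chain carbon bound to a saturated ring carbon, and in this assay compound 1 gives 5120 nM. Compound 2 `COCC[C@@H]1C[C@@H](c2ccc(Cl)c(Cl)c2)[C@H](NC(=O)c2cc(-c3c(Cl)cnn3C)c(Cl)o2)CN1`, with methoxymethyl in that place, gives 1060 nM. Compound 3 `Cn1ncc(Cl)c1-c1cc(C(=O)N[C@@H]2CN[C@H](CCO)C[C@H]2c2ccc(Cl)c(Cl)c2)oc1Cl`, with hydroxymethyl there, gives 610 nM, the lowest of the three numbers. Its gap to compound 2 lies within the scatter, whereas the step of an 8.4-fold lower number from compound 1 to compound 3 (0.92 log units; beyond the scatter) lies beyond it, as does a 4.8-fold lower number from compound 1 to compound 2 (0.68 log units; beyond the scatter). Compound 4 `Cn1ncc(Cl)c1-c1cc(C(=O)N[C@@H]2CN[C@H](CC(=O)NCCO)C[C@H]2c2ccc(Cl)c(Cl)c2)oc1Cl` has not yet been measured. It differs from compound 3 by (2-hydroxyethyl)carbamoyl in place of hydroxymethyl on a saturated chain carbon bound to a saturated ring carbon. Both measured steps bear on this change: swapping the carboxy group of compound 1 for either hydroxymethyl or methoxymethyl lowered the number modestly. Compound 4 brings a carbonyl back onto the chain, now within an amide rather than an acid, along with an added hydroxyl. Given the step of an 8.4-fold lower number from compound 1 to compound 3 (0.92 log units; beyond the scatter), the step expected for compound 4 is a 2.5-fold higher number from compound 3 to compound 4 (0.39 log units; beyond the scatter), a modest rise in the number. Compound 4 is therefore estimated at 1500 nM, with a range from 500 nM to 4500 nM.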

Compound 4, half-maximal inhibitory concentration: 1450 nM
Compound 4: the middle estimate sits 1.0-fold (0.01 log units) above what was measured; low and high end bracket the measured number.
By their numbers in this assay, from the lowest: compounds 3, 2 and 4 (each within the scatter of the next, the first and the last beyond it); then compound 1.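

Compound 4 shows that this place, on a saturated chain carbon bound to a saturated ring carbon, can carry the larger (2-hydroxyethyl)carbamoyl group in this assay at a modest cost against hydroxymethyl: a 2.4-fold higher number from compound 3 to compound 4 (0.38 log units; beyond the scatter). Against methoxymethyl the step is a 1.4-fold higher number from compound 2 to compound 4 (0.14 log units; within the scatter), so compound 2 and compound 4 cannot be told apart. Changing the acid into this amide, with (2-hydroxyethyl)amino in place of hydroxy on a carbonyl carbon, gives a 3.5-fold lower number from compound 1 to compound 4 (0.55 log units; beyond the scatter), so a carbonyl on the chain does not by itself hold the number as high as in compound 1.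

No evidence is available on what lies behind these steps. The compounds shown leave open how an amine at this place, or an unsubstituted amide, would compare with hydroxymethyl and with the (2-hydroxyethyl)carbamoyl group.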